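This account rests on a few compounds, and the source may have more. Where it says the series, first, only, none or still open, it means among the compounds named here.

Working notes on the sulfonamide series in a functional assay on OVCAR-3 cells (Homo sapiens) for antiproliferative activity, read by MTT assay, with a stated time of 24 h; a higher number here means a weaker inhibitor, a lower number a stronger inhibitor.

Compound 1 `O=c1[nH]cc(S(=O)(=O)Nc2ccccc2-c2cn(-c3ccccc3)nn2)c(=O)[nH]1` gives 6650 nM. Compound 2 `Cc1ccc(-n2cc(-c3ccccc3NS(=O)(=O)c3c[nH]c(=O)[nH]c3=O)nn2)cc1` differs from compound 1 by methyl in place of hydrogen on an aromatic carbon. Compound 2 gives 2190 nM; the step of a 3.0-fold lower number from compound 1 to compound 2 (0.48 log units; beyond the scatter). Compound 3 `O=c1[nH]cc(S(=O)(=O)Nc2ccc(-c3cn(-c4ccccc4)nn3)cc2)c(=O)[nH]1` gives 18000 nM, the highest number of the three; the difference between the core of compound 3 and the core of compound 1 is not broken down here.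

Compound 4 `Cc1ccccc1-n1cc(-c2ccc(NS(=O)(=O)c3c[nH]c(=O)[nH]c3=O)cc2)nn1` is not yet measured. It differs from compound 3 by methyl in place of hydrogen on an aromatic carbon. This is the same kind of change as from compound 1 to compound 2, but the place differs: there the methyl sits para to a large group, here ortho to a large group, so the earlier step is only a rough guide. Because the step of a 3.0-fold lower number from compound 1 to compound 2 (0.48 log units; beyond the scatter) was modest, compound 4 is expected to show a 2.0-fold lower number from compound 3 to compound 4 (0.30 log units; within the scatter), a somewhat smaller step than the earlier one given the different place. Compound 4 is estimated at 9000 nM, between 4000 nM and 20000 nM.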

Compound 4, half-maximal inhibitory concentration: 7310 nM
For compound 4 the middle estimate is 1.2-fold (0.09 log units) above the measured one; low and high end bracket the measured number.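

Methyl in place of hydrogen on an aromatic carbon carries over to the core of compound 3, with a 2.5-fold lower number from compound 3 to compound 4 (0.39 log units; beyond the scatter). In this assay the size of the step holds on both cores, although in compound 4 the methyl sits ortho to a large group: the same change on two cores in this assay, a 3.0-fold lower number (0.48 log units; beyond the scatter) from compound 1 to compound 2 and a 2.5-fold lower number (0.39 log units; beyond the scatter) from compound 3 to compound 4, 1.2-fold (0.09 log units) apart, within the scatter of two such steps. Among these compounds, these two pairs show only that the step is similar on these two cores; they do not show why the number falls or that the step would carry to other cores.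

Still open, from the compounds shown here alone, is whether an ethyl, a methoxy or a chlorine at the same place would act as methyl does. An amine or a carboxylic acid on that ring is also untested in the compounds shown.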